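The source may report more compounds than this note shows. Statements on the series, on what has been measured and on what is new or still open speak of the compounds shown alone.

Of the compounds shown here, three built on one shared core have been measured in an ADME assay on RAW264.7 cells (Mus musculus) for cytotoxicity, read by MTT assay, with a stated time of 72 h, tested at 50 uM; a lower number here means a weaker effect, a higher number a stronger effect of the compound at the concentration tested. Compound 1 `O=C(Cn1c(=O)oc2cc([N+](=O)[O-])ccc21)NCc1ccccn1` gives 21.8% in this assay. Compound 2 `O=C(Cn1c(=O)oc2cc([N+](=O)[O-])ccc21)NCc1cccs1` gives 36.6% in this assay. Compound 3 `O=C(Cn1c(=O)oc2cc([N+](=O)[O-])ccc21)Nc1ccccc1` gives 18% in this assay, the lowest of the three numbers shown, though its gap to compound 1 lies within the scatter, while a number 18.6 percentage points lower from compound 2 to compound 3 (beyond the scatter). Every measured step, a number 14.8 percentage points higher from compound 1 to compound 2 (beyond the scatter) and a number 3.8 percentage points lower from compound 1 to compound 3 (within the scatter) among them, changes only the group on the amide-type nitrogen and leaves the core untouched.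

Compound 4 `O=C(Cn1c(=O)oc2ccccc21)Nc1ccccc1` differs from compound 3 in the core itself: hydrogen in place of nitro on an aromatic carbon. For the measured compounds named here, no measured step touches this position, so the three compounds give no direct reading of how this assay answers to such a change. With the amide part held as in compound 3, the expected step for compound 4 is no change at the digits printed from compound 3 to compound 4 (within the scatter), not beyond the scatter. Compound 4 is therefore estimated at 18% in this assay, with a range from 6% to 30%.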

Compound 4, a percentage reported as inhibition, at one concentration (the size of the read-out at that concentration, not a potency): 35.1%
The estimate for compound 4 lay 17.1 percentage points below the measured number; measured number outside the range, above it.
By their numbers in this assay, from the lowest: compounds 3 and 1 (each within the scatter of the next); then compounds 4 and 2 (each within the scatter of the next).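

In this assay, for the compounds shown here, hydrogen in place of nitro on this aromatic carbon gives a number 17.1 percentage points higher from compound 3 to compound 4 (beyond the scatter), so the read-out answers to a change in the core as well as to the group on the amide-type nitrogen, the only place the earlier steps touched. Of this pair, the compound without the nitro group carries the higher number, a finding that rests on the phenyl amide alone. No measurement at hand accounts for this step.

Going by these compounds, whether the same change moves the number in the same direction with (thiophen-2-yl)methyl or (pyridin-2-yl)methyl on the amide-type nitrogen remains open. Also open is how an amine or a carboxylic acid on this aromatic carbon would read in this assay, so the compounds shown give only the two ends of a single swap, nitro and hydrogen.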